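Compound 4: benzoyl in place of phenylsulfonyl

The compounds below may be only part of what the source reports. "The series", "measured", "known", "first", "only" and "open" are said of these compounds alone.

Compound 3 `N#C/C(=C\c1c(-c2ccccc2)[nH]c2ccccc12)S(=O)(=O)c1ccccc1` gives 1400 nM in a functional assay on OVCAR-3 cells (Homo sapiens) for inhibition, read by sulforhodamine B assay, with a stated time of 48 h (on this read-out higher numbers stand for weaker inhibition of growth and lower numbers for stronger inhibition of growth), the second highest of the three numbers. Compound 1 `COc1ccc(-c2[nH]c3ccccc3c2/C=C(\C#N)S(=O)(=O)c2ccccc2)cc1` gives 244 nM and compound 2 `COc1ccc2[nH]c(-c3ccccc3)c(/C=C(\C#N)S(=O)(=O)c3ccccc3)c2c1` gives 5000 nM. The steps of a 5.7-fold higher number from compound 1 to compound 3 (0.76 log units; beyond the scatter) and a 3.6-fold lower number from compound 2 to compound 3 (0.55 log units; beyond the scatter) both concern hydrogen in place of methoxy on an aromatic carbon and leave the chain substituent untouched. Compound 4 `N#C/C(=C\c1c(-c2ccccc2)[nH]c2ccccc12)C(=O)c1ccccc1` differs from compound 3 by benzoyl in place of phenylsulfonyl on a double-bonded chain carbon bound to a double-bonded chain carbon and a triple-bonded carbon. Among the compounds with values here, no measured step bears on this change, so no direction can be read from it. For compound 4 the number expected is 1400 nM. The expected range for compound 4 runs from 300 nM to 6500 nM, wide for want of a comparable step. The step of no change at the digits printed from compound 3 to compound 4 (within the scatter) is thus expected to stay within the scatter.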

Compound 4, concentration for 50% growth inhibition: 2400 nM
Compound 4: the middle estimate sits 1.7-fold (0.23 log units) below what was measured, within the range that was stated.
By their numbers in this assay, from the lowest: compound 1; then compounds 3 and 4 (each within the scatter of the next); then compound 2.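

Within the data shown here, changing the chain substituent for the first time, benzoyl in place of phenylsulfonyl in this assay gives a 1.7-fold higher number from compound 3 to compound 4 (0.23 log units; within the scatter), so the sulfonyl group is not required on this chain carbon in this pair. The earlier steps shown here concerned only methoxy on the aromatic carbons and could not show this. No measurement here accounts for the result.

Still open, as far as these compounds go, is whether a carboxylic acid or an amine on this chain carbon would hold the number. Also open, from the compounds shown here alone, is whether the methoxy steps seen with phenylsulfonyl carry over to benzoyl.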